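Methylation of the phenolic oxygen and cytotoxicity

The compounds below may be only part of what the source reports. "The series", "measured", "known", "first", "only" and "open" are said of these compounds alone.

Measured compounds in an ADME assay on HEK293 cells (Homo sapiens) for cytotoxicity, read by reporter gene assay and resazurin assay, with a stated time of 48 h; on this read-out higher numbers stand for lower toxicity in this test and lower numbers for higher toxicity in this test:
- compound 1 (`O=C(Nc1ccccc1)c1cc(Br)ccc1O`): compound 1 gives 35000 nM.
- compound 2 (`O=C(Nc1cccc(Cl)c1)c1ccccc1O`): compound 2 gives 37000 nM.
- compound 3 (`COc1ccc(Br)cc1C(=O)Nc1ccccc1`): compound 3 gives only a limit of this assay, > 100000 nM.

Compound 3 is obtained from compound 1 by methyl in place of hydrogen on an oxygen on an aromatic ring. This change gives an at least 2.8-fold higher number from compound 1 to compound 3 (0.45 log units; beyond the scatter); the size is bounded only because of the limit of > 100000 nM in this assay, at which 1 of the 3 values shown sits. Compound 2 and compound 1 sit within the scatter of each other; how their two cores differ is not broken down here.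

Compound 4 (`COc1ccccc1C(=O)Nc1cccc(Cl)c1`) is not yet measured. Among the measured compounds shown here, it arises from compound 2 by methyl in place of hydrogen on an oxygen on an aromatic ring, the same change as the one between compound 1 and compound 3, at a place described in the same words. Resting on the earlier step of an at least 2.8-fold higher number from compound 1 to compound 3 (0.45 log units; beyond the scatter), a step of similar direction and size is expected from compound 2 to compound 4 in this assay, and a limit-only result is likely. The expected step is a 3.0-fold higher number from compound 2 to compound 4 (0.47 log units; beyond the scatter). Compound 4 is estimated at 110000 nM, between 40000 nM and 300000 nM.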

Compound 4, half-maximal cytotoxic concentration: > 100000 nM
Compound 4: a limit, no number; the forecaster's own chance of this, stated with the estimate: 55%; the middle value lies beyond the limit too.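

In this assay, hydroxy to methoxy on the core of compound 2 gives an at least 2.7-fold higher number from compound 2 to compound 4 (0.43 log units; beyond the scatter), so the direction seen on the core of compound 1 recurs on a second core: the same change on two cores in this assay, an at least 2.8-fold higher number (0.45 log units; beyond the scatter) from compound 1 to compound 3 and an at least 2.7-fold higher number (0.43 log units; beyond the scatter) from compound 2 to compound 4; the limit leaves it open whether they differ. Neither step has a known size, since both methoxy compounds stop at a limit of the assay: the limit of > 100000 nM in this assay, at which 2 of the 4 values shown sit. The pair therefore supports a shared direction on these two cores only, and shows neither that the size carries over nor that the change behaves the same way on other cores in the series.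

As far as these compounds go, whether a longer chain on the same oxygen, or an amine in place of the hydroxy, would give a step in this direction stays open. The compounds shown also leave open how any of these changes would read on a core carrying neither bromo nor chloro.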